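The compounds below may be only part of what the source reports. "The series", "measured", "known", "first", "only" and "open" are said of these compounds alone.

Three compounds that share one core and differ in a single aromatic substituent have so far been followed in an ADME assay on microsomes from liver (Rattus norvegicus) for metabolic stability, read by LC-MS, using NADPH, with a stated time of 90 min, tested at 1 uM (a lower number here means that the compound disappears faster, a higher number that the compound lasts longer), as a measure of how long they last. Compound 1 `Cn1cc(-c2cc(F)ccc2N2CCN(CCCc3c[nH]c4ccc(F)cc34)CC2)cn1` carries 1-methyl-1H-pyrazol-4-yl and gives 0.158 h in that test. Compound 2 `Fc1ccc(N2CCN(CCCc3c[nH]c4ccc(F)cc34)CC2)c(-c2ccsc2)c1` carries thiophen-3-yl and gives 0.408 h in the same test. Compound 3 `Fc1ccc(N2CCN(CCCc3c[nH]c4ccc(F)cc34)CC2)c(-c2cncnc2)c1` carries pyrimidin-5-yl and gives 0.11 h and so stands at the short end of the range, with a 1.4-fold lower number from compound 1 to compound 3 (0.16 log units; within the scatter) on one side and a 3.7-fold lower number from compound 2 to compound 3 (0.57 log units; beyond the scatter) on the other.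

Compound 4 `Fc1ccc(N2CCN(CCCc3c[nH]c4ccc(F)cc34)CC2)c(-c2ccoc2)c1` differs from compound 3 by furan-3-yl in place of pyrimidin-5-yl on an aromatic carbon and thus has furan-3-yl in place of pyrimidin-5-yl on an aromatic carbon. Within the data shown here, no furan-3-yl compound has been measured yet. The nearest guide is thiophen-3-yl, which in compound 2 gave a 2.6-fold higher number from compound 1 to compound 2 (0.41 log units; beyond the scatter) and stood apart from pyrimidin-5-yl by a 3.7-fold lower number from compound 2 to compound 3 (0.57 log units; beyond the scatter) in the opposite direction to the change now made. A partial reversal of that step is therefore expected, and the estimated step is a 2.3-fold higher number from compound 3 to compound 4 (0.36 log units; beyond the scatter) in this assay for this one change. The expected half-life of compound 4 is 0.25 h with 0.12 h and 0.5 h as the ends of its estimated range.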

Compound 4, half-life: 0.172 h
For compound 4 the middle estimate is 1.5-fold (0.16 log units) above the measured one; the measured number falls inside the stated range.
By their numbers in this assay, from the lowest: compounds 3, 1 and 4 (each within the scatter of the next); then compound 2.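

In this assay, the furan-3-yl group does not carry over the longer half-life seen with thiophen-3-yl (a 2.4-fold lower number from compound 2 to compound 4 (0.38 log units; beyond the scatter)), so at this place, ortho to a large group, that result does not extend to every five-membered aromatic ring. Furan-3-yl instead cannot be told apart from either pyrimidin-5-yl (a 1.6-fold higher number from compound 3 to compound 4 (0.19 log units; within the scatter)) or 1-methyl-1H-pyrazol-4-yl (a 1.1-fold higher number from compound 1 to compound 4 (0.04 log units; within the scatter)), and these three groups form one cluster at the short end of the range. Ring size therefore does not sort these compounds, since five-membered and six-membered rings share that cluster and compound 2, with its thiophen-3-yl group, is the only one of the four that stands apart from the rest.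

The compounds shown leave open whether a plain phenyl ring, a dimethylamino group or a morpholine ring at this place would stay with the cluster or match compound 2, and whether the thiophen-3-yl gain would hold on a different core. Nothing available here accounts for the gap between compound 2 and the other three compounds.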